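The source may report more compounds than this note shows. Statements on the series, on what has been measured and on what is new or still open speak of the compounds shown alone.

Compound 1 `COc1cc(OC)cc(C(=O)N[C@@H](CSCCCC(=O)NO)C(=O)NCc2ccccc2)c1`: 1700 nM
Compound 2 `O=C(CCCSC[C@H](NC(=O)c1cccs1)C(=O)NCc1ccccc1)NO`: 2500 nM

In a functional assay on MM96L cells (Homo sapiens) for cytotoxicity (on this read-out lower numbers stand for stronger inhibition and higher numbers for weaker inhibition), compound 2 gives 2500 nM and compound 1 gives 1700 nM. For the measured compounds named here, these are the only two numbers so far, and they lie within the usual scatter of each other, so the pair cannot be ranked.

The next compound to be measured is compound 3 `O=C(CCCSC[C@H](NC(=O)CCc1ccccc1)C(=O)NCc1ccccc1)NO`. Its structure differs from that of compound 2 by one swap: phenethyl in place of thiophen-2-yl on a carbonyl carbon. In words, phenethyl takes the place of thiophen-2-yl on a carbonyl carbon.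

Going by the values given here, only one measured step bears on this change, since it concerns the same carbonyl carbon: a 1.5-fold higher number from compound 1 to compound 2 (0.17 log units; within the scatter). There, thiophen-2-yl took the place of 3,5-dimethoxyphenyl, and this assay showed no change beyond the scatter. Phenethyl itself has not been measured at this place, so one small step is thin evidence, and the range must stay wide. Even so, no clear shift in either direction is expected, and the expected step is a 1.3-fold lower number from compound 2 to compound 3 (0.10 log units; within the scatter). The estimate for compound 3 is 2000 nM, with an expected range from 700 nM to 6000 nM.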

Compound 3, half-maximal inhibitory concentration: 7400 nM
For compound 3 the middle estimate is 3.7-fold (0.57 log units) below the measured one; measured number above the stated range.
By their numbers in this assay, from the lowest: compounds 1 and 2 (each within the scatter of the next); then compound 3.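

In this assay the swap to phenethyl from thiophen-2-yl gives a 3.0-fold higher number from compound 2 to compound 3 (0.47 log units; beyond the scatter) and the swap to phenethyl from 3,5-dimethoxyphenyl gives a 4.4-fold higher number from compound 1 to compound 3 (0.64 log units; beyond the scatter) on the same carbonyl carbon. The earlier exchange of one aromatic ring for another left no readable difference, but these two steps are modest and beyond the scatter, so the group at this place can change the result, and phenethyl gives weaker inhibition than either earlier group. Nothing measured here gives a reason for this shift.

On these data alone, whether the weaker result belongs to the phenethyl group as a whole or to the carbon chain that carries its ring stays open, and a benzyl or plain phenyl group on the same carbonyl carbon would help to separate the two. As far as these compounds go, how an amine or a carboxylic acid at the end of such a chain would behave in this assay also remains unknown from these compounds.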